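This account rests on a few compounds, and the source may have more. Where it says the series, first, only, none or still open, it means among the compounds named here.

Series notes. Compound 1 `O=C1NC(=O)N(/N=C/c2ccc(-c3ccc([N+](=O)[O-])cc3)o2)C1O` carries a nitro on an aromatic carbon of the shared core. In a functional assay on the whole organism (Gastrocnemius, strain Sprague-Dawley) for inhibition, with Rattus norvegicus as the target (on this read-out lower numbers stand for an effect already at smaller amounts and higher numbers for an effect only at larger amounts of compound), compound 1 gives 0.015 umol/kg, the lowest of the two numbers in hand. Compound 2 `O=C1NC(=O)N(/N=C/c2ccc(-c3cccc(C(F)(F)F)c3)o2)C1O` gives 0.096 umol/kg in this assay, a higher number. Compound 3 `CC(=O)Nc1ccc(-c2ccc(/C=N/N3C(=O)NC(=O)C3O)o2)cc1` reaches only a limit of this assay, > 0.107 umol/kg. Among the compounds with values here, the single measured step that bears on the present change runs an at least 7.1-fold higher number from compound 1 to compound 3 (0.85 log units; beyond the scatter), bounded by the limit of > 0.107 umol/kg in this assay, at which 1 of the 3 values shown sits. Compound 4 `O=C1NC(=O)N(/N=C/c2ccc(-c3ccc(F)cc3)o2)C1O` differs from compound 1 by fluoro in place of nitro on an aromatic carbon. Since the acetamido step from compound 1 gave an at least 7.1-fold higher number from compound 1 to compound 3 (0.85 log units; beyond the scatter) and compound 2 also sits higher, an upward step beyond the scatter is expected for compound 4, a 4.0-fold higher number from compound 1 to compound 4 (0.60 log units; beyond the scatter). The estimate for compound 4 in this assay is 0.06 umol/kg, with a range of 0.02 umol/kg to 0.2 umol/kg.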

Compound 4, dose for half-maximal effect: 0.091 umol/kg
Compound 4: the middle estimate sits 1.5-fold (0.18 log units) below what was measured; measured number inside the range.
By their numbers in this assay, from the lowest: compound 1; then compounds 4 and 2 (each within the scatter of the next). At a limit, above all of these: compound 3.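

Fluoro in place of nitro on this aromatic carbon, para to a large group, gives a 6.1-fold higher number from compound 1 to compound 4 (0.78 log units; beyond the scatter) in this assay, so leaving nitro now has a measured size and not only a bound. Both replacements shown at this position, acetamido and fluoro, raise the number from compound 1. Compound 3 stands at a limit: the limit of > 0.107 umol/kg in this assay, at which 1 of the 4 values shown sits. Fluoro in place of acetamido on an aromatic carbon gives an at least 1.1-fold lower number from compound 3 to compound 4 (0.07 log units; that floor lies within the scatter) in this assay, so this step stays a bound and not a measured size.

As far as these compounds go, whether any other group here, such as a nitrile, a carboxylic acid or an amine, would hold the number of compound 1 stays open. From the compounds shown here alone, whether moving nitro to another carbon of this ring would do so stays open too.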